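The source may hold more compounds than are shown below. What is called first, only, known or untested is meant among the compounds shown, and "the series" means these compounds.

Measured so far in a functional assay on the whole organism (strain Albino Swiss CD1) with Mus musculus as the target; on this read-out lower numbers stand for an effect already at smaller amounts and higher numbers for an effect only at larger amounts of compound:
compound 1 `CCC(C(=O)NCc1cccc(F)c1)N1C(=O)CCC1=O` gives 47.4 mg/kg
compound 2 `CCC(C(=O)NCc1ccc(F)cc1)N1C(=O)CCC1=O` gives 83.4 mg/kg
compound 3 `CCC(C(=O)NCc1cccc(C(F)(F)F)c1)N1C(=O)CCC1=O` gives 77.4 mg/kg

The two cores differ as 4-fluorophenyl in place of 3-fluorophenyl on a saturated chain carbon bound to an amide-type nitrogen; the corresponding step is a 1.8-fold higher number from compound 1 to compound 2 (0.25 log units; within the scatter). From compound 1 to compound 3 the change is trifluoromethyl in place of fluoro on an aromatic carbon, and it gave a 1.6-fold higher number from compound 1 to compound 3 (0.21 log units; within the scatter). Compound 4 `CCC(C(=O)NCc1ccc(C(F)(F)F)cc1)N1C(=O)CCC1=O` is not yet measured; it carries the corresponding change made on compound 2, namely (trifluoromethyl in place of fluoro on an aromatic carbon). The two places are not the same word for word: in compound 3 the entering group sits meta to a large group, in compound 4 it sits para to a large group, so this is the same kind of change rather than the same change. None of the three measured values lies beyond the scatter from any other, so the data do not rank them. Beside the earlier step, the step from compound 2 to compound 4 in this assay is expected to be a 1.4-fold higher number from compound 2 to compound 4 (0.16 log units; within the scatter), resting on compound 3 having shown a 1.6-fold higher number from compound 1 to compound 3 (0.21 log units; within the scatter) on the other core, while the difference in place leaves room for a wider outcome. Compound 4 is therefore expected to give about 120 mg/kg, with a range from 60 mg/kg to 240 mg/kg.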

Compound 4, dose for half-maximal effect: 80.4 mg/kg
Compound 4: the middle estimate sits 1.5-fold (0.17 log units) above what was measured; the measured number falls inside the stated range.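

In this assay, trifluoromethyl in place of fluoro on the core of compound 2 gives a 1.0-fold lower number from compound 2 to compound 4 (0.02 log units; within the scatter), and beside the earlier step on the core of compound 1 the two cannot be told apart: the same change on two cores in this assay, a 1.6-fold higher number (0.21 log units; within the scatter) from compound 1 to compound 3 and a 1.0-fold lower number (0.02 log units; within the scatter) from compound 2 to compound 4, 1.7-fold (0.23 log units) apart, within the scatter of two such steps

The change therefore carries from one core to the other in this series with no detectable difference between the two steps. Among the compounds shown here, this does not show that the change is without effect or that its outcome is the same on both cores, since neither step rises above the scatter, only two pairs are available, and a small real difference could lie hidden within it.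

The compounds shown leave open whether a chloro, methoxy or nitrile group on the aromatic ring would give a step beyond the scatter. Also open, as far as these compounds go, is how a longer chain on the saturated carbon bound to the ring nitrogen would read out in this assay.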